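Shifting the acid and methyl around the aryl ether ring

The compounds below may be only part of what the source reports. "The series", "measured", "known", "first", "only" and "open" are said of these compounds alone.

Compound 1 `Cc1c(OCCCCOc2ccc(C(=O)O)cc2F)ccc(C(=O)CC(C)C)c1O`: 1420 nM
Compound 3 `Cc1cc(OCCCCOc2ccc(C(=O)CC(C)C)c(O)c2C)ccc1C(=O)O`: 3910 nM
Compound 2 `COC(=O)c1ccc(OCCCCOc2ccc(C(=O)CC(C)C)c(O)c2C)cc1`: result in an assay on HEK293 cells for positive allosteric modulation of metabotropic glutamate receptor 3 (Rattus norvegicus), read by thallium flux, with a stated time of 2.5 min (on this read-out lower numbers stand for an effect already at smaller amounts and higher numbers for an effect only at larger amounts of compound), is "not determined" (no result reported)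

Of the two numbers in this assay, compound 3 is the higher, its nearest neighbour being compound 1, with a 2.8-fold higher number from compound 1 to compound 3 (0.44 log units; beyond the scatter) between them. Compound 4 `Cc1ccc(C(=O)O)cc1OCCCCOc1ccc(C(=O)CC(C)C)c(O)c1C` differs from compound 3 only in the aryl group on the ether oxygen: 5-carboxy-2-methylphenyl in place of 4-carboxy-3-methylphenyl on an oxygen on a saturated carbon. For the measured compounds named here, the single measured step, from compound 1 to compound 3, swapped substituents on that same ring and moved the number modestly upward. Going by the values given here, no measured step moves the carboxy group itself, so the direction is uncertain; a step of about the same modest size, in either direction, is expected, written as a 1.3-fold higher number from compound 3 to compound 4 (0.11 log units; within the scatter). Compound 4 is therefore estimated at 5000 nM, between 1500 nM and 16000 nM.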

Compound 4, half-maximal effective concentration: > 10000 nM
Compound 4 ended at the assay's limit (the forecaster's own chance of this, stated with the estimate: 25%); middle value at least 2.0-fold (0.30 log units) from the limit.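

The reading for compound 4 in this assay is a limit, not a number: the limit of > 10000 nM in this assay, at which 1 of the 4 values shown sits.

Even so, the result shows that this ring's substitution pattern matters, since joining the same atoms differently, with 5-carboxy-2-methylphenyl in place of 4-carboxy-3-methylphenyl, gives an at least 2.5-fold higher number from compound 3 to compound 4 (0.40 log units; beyond the scatter). Against 4-carboxy-2-fluorophenyl, the change gives an at least 7.0-fold higher number from compound 1 to compound 4 (0.84 log units; beyond the scatter).

From the compounds shown here alone, how far beyond the limit compound 4 lies remains open, and so does the true size of both steps. Also open, going by these compounds, is how an amide or an amine would read in place of the carboxylic acid on this ring.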